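Replacing the side chain on the ring amine

This account rests on a few compounds, and the source may have more. Where it says the series, first, only, none or still open, it means among the compounds named here.

Measured in a functional assay on A2780 cells (Homo sapiens) for antiproliferative activity; on this read-out lower numbers stand for stronger inhibition and higher numbers for weaker inhibition
- compound 1 `Cc1ccc2c(c1C)CN(CCCCN)CC2c1ccccc1`: 2370 nM
- compound 2 `Cc1ccc2c(c1C)CN(CCCCN(C)C)CC2c1ccccc1`: 1860 nM

Among the compounds with values here, only two numbers exist so far, and compound 2 stands level with compound 1: the measured step is a 1.3-fold lower number from compound 1 to compound 2 (0.11 log units; within the scatter). Neither compound can be ranked above the other.

The next compound is compound 3 `Cc1ccc2c(c1C)CN(C(=O)N(C)C)CC2c1ccccc1`. The change is dimethylcarbamoyl in place of 4-(dimethylamino)butyl on an amine nitrogen in a ring. Dimethylcarbamoyl takes the place of 4-(dimethylamino)butyl on an amine nitrogen in a ring, two ring bonds from the ring atom that bears a phenyl group.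

Within the data shown here, the single measured step bears on this only in part. It alters the end of the chain and keeps the chain itself, whereas compound 3 loses the chain entirely. Among the measured compounds shown here, no measured compound lacks that chain, so the data give no direct size for this change. A step beyond the scatter is nevertheless expected, toward a higher number and weaker inhibition, though with wide uncertainty. The estimated change is a 3.2-fold higher number from compound 2 to compound 3 (0.51 log units; beyond the scatter). For compound 3 the expected value is 6000 nM, with an estimated range of 2000 nM to 25000 nM.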

Compound 3, half-maximal inhibitory concentration: 1200 nM
Compound 3: the middle estimate sits 5.0-fold (0.70 log units) above what was measured, and the stated range ends above it.
By their numbers in this assay, from the lowest: compounds 3, 2 and 1 (each within the scatter of the next).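

In this assay, dimethylcarbamoyl in place of 4-(dimethylamino)butyl on the amine nitrogen in the ring gives a 1.6-fold lower number from compound 2 to compound 3 (0.19 log units; within the scatter) and the same group in place of 4-aminobutyl gives a 2.0-fold lower number from compound 1 to compound 3 (0.30 log units; within the scatter) so all three compounds stand level. The earlier step altered only the end of the chain, whereas these two steps remove the whole chain, and at this position neither 4-aminobutyl nor 4-(dimethylamino)butyl is needed to keep the number in this range; this holds only for the three compounds shown, and none of them goes against it. No measurement at hand accounts for this outcome.

On these data alone, what remains open is how far this position tolerates change: a bare ring amine bearing only hydrogen, an acetyl group, a longer chain or a chain ending in a carboxylic acid could each fall inside or outside this range. Also open, as far as these compounds go, is whether the level result between dimethylcarbamoyl and the two amine-ended chains would persist with a different substituent in place of the phenyl group on the shared core.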